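Swapping a Methoxy for Fluoro on a Benzylidene Ring

This account rests on a few compounds, and the source may have more. Where it says the series, first, only, none or still open, it means among the compounds named here.

Measured compounds:
Compound 1, `Cc1ccc(/C=C2\CCC/C(=C\c3ccccc3[N+](=O)[O-])C2=O)cc1`: 7770 nM
Compound 2, `COc1ccc(/C=C2\CCC/C(=C\c3ccccc3[N+](=O)[O-])C2=O)cc1`: 42400 nM

Both compounds were tested in a functional assay on L1210 cells (Mus musculus) for cytotoxicity, with a stated time of 48 h; a higher number here means a weaker inhibitor, a lower number a stronger inhibitor. Within the data shown here, compound 2 gives the higher of the two numbers, and its one neighbour in this small set is compound 1, where the change was a 5.5-fold higher number from compound 1 to compound 2 (0.74 log units; beyond the scatter). Compound 2 therefore stands as the weaker of the two measured compounds.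

Compound 3, `O=C1/C(=C/c2ccc(F)cc2)CCC/C1=C\c1ccccc1[N+](=O)[O-]`, has not yet been measured. It differs from compound 2 in a single place: fluoro in place of methoxy on an aromatic carbon. Among the measured compounds shown here, only one measured step bears on this change, the replacement of methyl by methoxy, which made the number larger from compound 1 to compound 2. Fluoro is neither of those groups, so that step gives only a rough guide; it does show that what sits at this position on the shared core can shift the number by a modest amount. Reversing part of that shift seems the more likely outcome, and compound 3 is expected to give 15000 nM, with a range from 4000 nM to 60000 nM. That estimate amounts to a 2.8-fold lower number from compound 2 to compound 3 (0.45 log units; beyond the scatter).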

Compound 3, half-maximal inhibitory concentration: 8400 nM
The estimate for compound 3 lay 1.8-fold (0.25 log units) above the measured number; the measured number falls inside the stated range.
By their numbers in this assay, from the lowest: compounds 1 and 3 (each within the scatter of the next); then compound 2.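

In this assay, putting fluoro in place of methoxy on this aromatic carbon gives a 5.0-fold lower number from compound 2 to compound 3 (0.70 log units; beyond the scatter) and so runs opposite to the earlier change from methyl to methoxy. The fluoro and methyl compounds cannot be told apart, with a 1.1-fold higher number from compound 1 to compound 3 (0.03 log units; within the scatter) and thus no real difference between them, so among the three groups tried here methoxy alone stands apart, and compound 2 is the weakest of the three, its steps to both others being beyond the scatter. Nothing given here explains why methoxy differs from the other two groups.

Going by these compounds, whether a hydroxyl group, an amine or a longer chain such as ethoxy at this position would behave like methoxy or like methyl and fluoro remains open. Also open, on these data alone, is whether the same three groups would keep this pattern if another part of the shared core were changed, since all three compounds carry the same remainder.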